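The source may hold more compounds than are shown below. What is called first, only, known or untested is meant among the compounds shown, and "the series" means these compounds.

Compound 1 `CC(C)OC(=O)N1CCC(Oc2ncnc3c2CCN3c2ccc(S(C)(=O)=O)cn2)CC1` and compound 2 `CC(C)OC(=O)N1CCC(Oc2ncnc3c2CCN3c2ccc(C#N)cn2)CC1` share one core and differ only in the group carried on the pyridine ring. In a functional assay on CHO-K1 cells for agonist activity at Glucose-dependent insulinotropic receptor (Homo sapiens), read by a luciferase reporter, with a stated time of 5 h (on this read-out lower numbers stand for an effect already at smaller amounts and higher numbers for an effect only at larger amounts of compound), compound 1 gives 126 nM, and in this assay compound 2 gives 794 nM. Among the compounds with values here, the step of a 6.3-fold higher number from compound 1 to compound 2 (0.80 log units; beyond the scatter) is the only measured change so far, and it leaves compound 2 with the highest of the two numbers, its nearest neighbour being compound 1.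

Compound 3 `Cc1ncccc1N1CCc2c(OC3CCN(C(=O)OC(C)C)CC3)ncnc21` arises from compound 2 by a further change at the same point: 2-methylpyridin-3-yl in place of 5-cyanopyridin-2-yl on a nitrogen on an aromatic ring in a ring. Within the data shown here, no measured step covers this change. Among the measured compounds shown here, the one known step, a 6.3-fold higher number from compound 1 to compound 2 (0.80 log units; beyond the scatter), shows that swapping the group on that pyridine can move the number by a modest amount, but it gives no direction for replacing the whole pyridine with a differently joined one carrying a methyl. For this reason compound 3 is expected to sit above compound 2, as a step of a 2.5-fold higher number from compound 2 to compound 3 (0.40 log units; beyond the scatter), with wide uncertainty. Compound 3 is estimated at 2000 nM, within a range from 400 nM to 10000 nM.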

Compound 3, half-maximal effective concentration: > 10000 nM
Compound 3: only a limit was reported (the forecaster's own chance of this, stated with the estimate: 20%); middle value at least 5.0-fold (0.69 log units) from the limit.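

The reading for compound 3 in this assay is a limit of the assay and not a number: the limit of > 10000 nM in this assay, at which 1 of the 3 values shown sits.

Putting 2-methylpyridin-3-yl on this nitrogen gives an at least 12-fold higher number from compound 2 to compound 3 (1.10 log units; beyond the scatter) and an at least 79-fold higher number from compound 1 to compound 3 (1.89 log units; beyond the scatter), both large steps. Within the data shown here, until now the only change at this position was the modest 6.3-fold higher number from compound 1 to compound 2 (0.80 log units; beyond the scatter), in which the group on the pyridine changed while the way the pyridine was joined stayed the same. Compound 3 shows that exchanging the whole aromatic group here can carry the read-out up to the limit of the assay, so this position does not accept every pyridine equally.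

The change to compound 3 alters two things at once, the way the pyridine is joined and the group it carries, and the compounds shown cannot separate the two. On these data alone, it also remains open how the number would move with an amine or a carboxylic acid in place of the cyano or methylsulfonyl group on the pyridine of compound 2 or compound 1.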